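This account rests on a few compounds, and the source may have more. Where it says the series, first, only, none or still open, it means among the compounds named here.

Measured so far:
- compound 2 `CC(C)(C)[C@@H](N)C(=O)NCc1ccccc1`: in a functional assay on the whole organism (strain albino Sprague-Dawley) with Rattus norvegicus as the target, in the maximal electroshock model (on this read-out lower numbers stand for an effect already at smaller amounts and higher numbers for an effect only at larger amounts of compound), it gives — compound 2 gives 11 mg/kg
- compound 1 `COC[C@@H](N)C(=O)NCc1ccc(OCc2cccc(F)c2)cc1`: compound 1 gives 13 mg/kg
- compound 3 `CC(C)[C@H](N)C(=O)NCc1ccc(COc2cccc(F)c2)cc1`: compound 3 gives only a limit of the assay, > 30 mg/kg

Of the two numbers that were actually measured, compound 2 stands at the lowest. Its nearest neighbour is compound 1, whose number lies within the usual scatter of repeated measurements, so no order between compound 2 and compound 1 can be claimed. For compound 3 the assay reports a limit rather than a number; one of the three results sits at the limit of > 30 mg/kg in this assay, at which 1 of the 3 values shown sits.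

Compound 4 `CC(C)(C)[C@@H](N)C(=O)NCc1ccc(C(F)(F)F)cc1` has not yet been measured in this assay. Compared with compound 2 the change is trifluoromethyl in place of hydrogen on an aromatic carbon. Within the data shown here, no measured pair of compounds shows this change, so the expected step is none beyond the scatter, with a small move in either direction possible: no change at the digits printed from compound 2 to compound 4 (within the scatter). Compound 4 is therefore expected to give about 11 mg/kg, with a range from 4 mg/kg to 30 mg/kg.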

Compound 4, dose for half-maximal effect: < 30 mg/kg
Compound 4: no number, only a limit; the forecaster's own chance of this, stated with the estimate: 15%; the middle value lies beyond the limit too.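

In this assay compound 4 gives only a limit of the assay, < 30 mg/kg, not a number, so the step to it from compound 2 cannot be read. The compounds shown leave open whether trifluoromethyl in place of hydrogen on an aromatic carbon changes the effective dose at all, and in which direction.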